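A few compounds are considered here, and "the series" means these few. Any claim that something is new, unique, unknown or untested is made for them only; others in the source may bear on it.

Measured so far:
Compound 1 `CC(C)(O)c1cncc(-n2ncc3ccccc32)c1` gives 15 nM in an assay on cells for inhibition of cytochrome P450 11B2, mitochondrial (Homo sapiens), read by HTRF, with stated times of 1 h and 3 h; on this read-out higher numbers stand for weaker inhibition and lower numbers for stronger inhibition.
Compound 2 `CC(C)(O)c1cncc(-n2ncc3ccc(F)cc32)c1` gives 78.5 nM in this assay.

Among the measured compounds shown here, of these two numbers compound 2 holds the higher one; its only neighbour is compound 1, and the step of a 5.2-fold higher number from compound 1 to compound 2 (0.72 log units; beyond the scatter) lies beyond the scatter. Compound 3 `CC(C)(O)c1cncc(-n2ncc3ccc(C(F)(F)F)cc32)c1` is compound 2 with trifluoromethyl in place of fluoro on an aromatic carbon. For the measured compounds named here, only one measured step bears on this change, a 5.2-fold higher number from compound 1 to compound 2 (0.72 log units; beyond the scatter), in which a fluoro entered at this same place on the core of compound 1 and the number rose by a modest but clear margin. Nothing measured shows what a trifluoromethyl does at this place. The group that enters is counted larger than the fluoro it replaces, and the fluoro itself already raised the number in the step of a 5.2-fold higher number from compound 1 to compound 2 (0.72 log units; beyond the scatter), so a further rise is expected rather than a return toward compound 1. A step of about a 1.9-fold higher number from compound 2 to compound 3 (0.28 log units; within the scatter) toward weaker inhibition is expected, though a step within the scatter would not surprise. The estimate for compound 3 is 150 nM, with a range from 40 nM to 600 nM.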

Compound 3, half-maximal inhibitory concentration: 2300 nM
Beside the measured number, compound 3's estimate is 15-fold (1.19 log units) below it, and the stated range ends below it.
By their numbers in this assay, from the lowest: compound 1; then compound 2; then compound 3.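

In this assay this place on the shared core turns out to be far less forgiving than the first step alone could show: hydrogen to fluoro gave a 5.2-fold higher number from compound 1 to compound 2 (0.72 log units; beyond the scatter), whereas the further change to trifluoromethyl gave the much larger a 29-fold higher number from compound 2 to compound 3 (1.47 log units; beyond the scatter). Taken from the unsubstituted compound, the whole change amounts to a 150-fold higher number from compound 1 to compound 3 (2.19 log units; beyond the scatter), so among these three compounds the number rises with each replacement at this aromatic carbon, meta to a fused ring and para to a fused ring, and none goes against that order. Nothing available here accounts for why the second step is so much larger than the first.

With only hydrogen, fluoro and trifluoromethyl at this place, the compounds shown cannot tell whether the rise follows the count of heavy atoms or some other feature of the groups, and a methyl, a chlorine, a methoxy group, a nitrile or an amine at the same carbon would help to separate these readings. They also leave open whether other places on the shared core respond in the same way to the same replacements.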